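The source may hold more compounds than are shown below. What is called first, only, known or untested is meant among the compounds shown, and "the series" means these compounds.

In a functional assay on MCF7 cells (Homo sapiens) for cytotoxicity, read by MTT assay, with a stated time of 48 h (a higher number here means a weaker inhibitor, a lower number a stronger inhibitor), compound 1 `Cc1ncc([N+](=O)[O-])n1CCSc1nnc(-c2ccccc2F)o1` gives 20500 nM and compound 2 `Cc1ncc([N+](=O)[O-])n1CCSc1nnc(-c2cccnc2)o1` gives 28700 nM. Among the compounds with values here, these are the only two numbers, and they lie within the scatter of each other, so compound 2 stands level with compound 1 and has no clearly separated neighbour.

Compound 3 `Cc1ncc([N+](=O)[O-])n1CCSc1nnc(-c2ccc(N)nc2)o1` differs from compound 2 by one change: amino in place of hydrogen on an aromatic carbon. This is amino in place of hydrogen on an aromatic carbon, turning pyridin-3-yl into 6-aminopyridin-3-yl.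

Within the data shown here, only one measured step bears on this change, and only loosely. That step, a 1.4-fold higher number from compound 1 to compound 2 (0.15 log units; within the scatter), swaps the whole aromatic group on the shared core and does not leave the scatter. Among the measured compounds shown here, no measured step adds an amino group, so the data give no direction for this change. No shift beyond the scatter is expected in this assay, in either direction, though two numbers support only a wide range.

The expected step is a 1.1-fold lower number from compound 2 to compound 3 (0.06 log units; within the scatter). For compound 3 the estimated value is 25000 nM, with an expected range of 10000 nM to 60000 nM.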

Compound 3, half-maximal inhibitory concentration: 26800 nM
For compound 3 the middle estimate is 1.1-fold (0.03 log units) below the measured one; the measured number falls inside the stated range.
By their numbers in this assay, from the lowest: compounds 1, 3 and 2 (each within the scatter of the next).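

In this assay, amino in place of hydrogen on the aromatic carbon next to the ring nitrogen and para to a large group gives a 1.1-fold lower number from compound 2 to compound 3 (0.03 log units; within the scatter), so this position of the pyridin-3-yl group tolerates an added amino group without a shift beyond the scatter. The comparison with the 2-fluorophenyl compound gives a 1.3-fold higher number from compound 1 to compound 3 (0.12 log units; within the scatter), which places 6-aminopyridin-3-yl level with both earlier aromatic groups on the shared core and leaves all three compounds without a clearly separated neighbour. No independent data are available to account for this flat result.

On these data alone, it remains open whether a bulkier or charged substituent at this same carbon, such as a dimethylamino group or a carboxylic acid, would move the number beyond the scatter, or whether the insensitivity holds only for a small amino group. Also unresolved is whether changes away from the aromatic group, such as a longer chain in place of the present link to the sulfur atom, would separate any compound from this level cluster.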